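Working notes: acetamido in place of ethoxy

The source may report more compounds than this note shows. Statements on the series, on what has been measured and on what is new or still open speak of the compounds shown alone.

Measured in a functional assay on MCF7 cells (Homo sapiens) for antiproliferative activity, read by MTT assay, with a stated time of 48 h; on this read-out higher numbers stand for weaker inhibition and lower numbers for stronger inhibition:
- Compound 1 `COc1ccc(-c2c(Nc3ccc(NC(C)=O)cc3)c3ccccc3oc2=O)cc1` gives > 100000 nM, which is a limit.
- Compound 2 `COc1ccc(-c2c(Nc3ccc(C)c(O)c3)c3ccc(OC)cc3oc2=O)cc1` gives 34400 nM.
- Compound 3 `CCOc1ccc(Nc2c(-c3ccc(OC)cc3)c(=O)oc3cc(OC)ccc23)cc1` gives 24300 nM.

Among the measured compounds shown here, compound 2 and compound 3 hold the only two numbers and lie within the scatter of each other, with a 1.4-fold lower number from compound 2 to compound 3 (0.15 log units; within the scatter). For compound 1 the entry is the limit of > 100000 nM in this assay, at which 1 of the 3 values shown sits.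

Compound 4 `COc1ccc(-c2c(Nc3ccc(NC(C)=O)cc3)c3ccc(OC)cc3oc2=O)cc1` keeps the core of compound 3 and takes acetamido in place of ethoxy on an aromatic carbon, para to a large group: acetamido in place of ethoxy on an aromatic carbon.

For the measured compounds named here, the one measured step at this site is a 1.4-fold lower number from compound 2 to compound 3 (0.15 log units; within the scatter), so exchanging these groups has not yet moved the number beyond the scatter. Going by the values given here, compound 1 is the only measured compound with 4-acetamidophenyl, and its > 100000 nM is a limit. On that evidence a small move towards weaker inhibition in this assay is expected, and the expected step is a 1.9-fold higher number from compound 3 to compound 4 (0.27 log units; within the scatter). For compound 4 the estimated value is 45000 nM, with an expected range of 18000 nM to 100000 nM.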

Compound 4, half-maximal inhibitory concentration: 85800 nM
For compound 4 the middle estimate is 1.9-fold (0.28 log units) below the measured one; the range from low to high includes it.
By their numbers in this assay, from the lowest: compounds 3 and 2 (each within the scatter of the next); then compound 4. At a limit, above all of these: compound 1.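

At this site, on an aromatic carbon para to a large group, the exchange now moves the number beyond the scatter in this assay (a 3.5-fold higher number from compound 3 to compound 4 (0.55 log units; beyond the scatter)), whereas the earlier step here stayed within it (a 1.4-fold lower number from compound 2 to compound 3 (0.15 log units; within the scatter)). The second comparison at this site points the same way (a 2.5-fold higher number from compound 2 to compound 4 (0.40 log units; beyond the scatter)), so 4-acetamidophenyl gives weaker inhibition than either 4-ethoxyphenyl or 3-hydroxy-4-methylphenyl on the shared core. Methoxy in place of hydrogen on an aromatic carbon gives only a floor (an at least 1.1-fold lower number from compound 1 to compound 4 (0.06 log units; that floor lies within the scatter)), and that floor rests on a limit: the limit of > 100000 nM in this assay, at which 1 of the 4 values shown sits.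

From the compounds shown here alone, whether the weaker inhibition follows the amide hydrogen, the carbonyl or the acetamido group as a whole remains open. An amine or a propoxy chain in the same place would help separate these readings.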